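Shortening the thioether chain on a shared core

This account rests on a few compounds, and the source may have more. Where it says the series, first, only, none or still open, it means among the compounds named here.

Compound 3 `CCCCSc1nnc(COc2ccccc2C2=NOC(c3ccc(Cl)cc3Cl)C2)n1NC(=O)c1ccccc1` stands highest of the two numbers in an ADME assay (MDM cells, Homo sapiens) for cytotoxicity, read by resazurin assay, with a stated time of 3 days (on this read-out lower numbers stand for stronger inhibition and higher numbers for weaker inhibition), giving 2.5 ug/mL; its nearest neighbour, compound 1 `CCSc1nnc(COc2ccccc2C2=NOC(c3ccc(Cl)cc3Cl)C2)n1NC(=O)c1ccccc1`, gives 1.8 ug/mL, a gap within the scatter. Compound 2 `C/C=C/Sc1nnc(COc2ccccc2C2=NOC(c3ccc(Cl)cc3Cl)C2)n1NC(=O)c1ccccc1` has no result in this assay, reported as "not determined" (no result reported). Compound 4 `CSc1nnc(COc2ccccc2C2=NOC(c3ccc(Cl)cc3Cl)C2)n1NC(=O)c1ccccc1` goes the other way along the chain: hydrogen in place of propyl on a saturated chain carbon bound to a sulfur. For the measured compounds named here, one measured step bears on it, the chain lengthening a 1.4-fold higher number from compound 1 to compound 3 (0.14 log units; within the scatter), which stayed within the scatter, so a shortening of the same chain is expected to move the number little if at all in this assay. Compound 4 is therefore estimated at 2 ug/mL, with a range from 0.9 ug/mL to 4.5 ug/mL. The step this expectation implies is a 1.3-fold lower number from compound 3 to compound 4 (0.10 log units; within the scatter).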

Compound 4, half-maximal inhibitory concentration: 2.2 ug/mL
Beside the measured number, compound 4's estimate is 1.1-fold (0.04 log units) below it, and the stated range covers the measured number.
By their numbers in this assay, from the lowest: compounds 1, 4 and 3 (each within the scatter of the next).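

Cutting the butylsulfanyl chain to methylsulfanyl gives a 1.1-fold lower number from compound 3 to compound 4 (0.06 log units; within the scatter) in this assay, and replacing the ethylsulfanyl chain with methylsulfanyl gives a 1.2-fold higher number from compound 1 to compound 4 (0.09 log units; within the scatter) on the same read-out. The shortening is thus measured directly, and compounds 1, 3 and 4 show no dependence on chain length at this sulfur, since all three lie within the scatter of one another. Nothing available explains why this position tolerates the change. The compounds shown leave open whether a chain longer than butyl, or one carrying an amine or a carboxylic acid, would stay this close.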